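Chain-end group exchange in the shared core series: compound 4

The source may hold more compounds than are shown below. What is called first, only, known or untested is meant among the compounds shown, and "the series" means these compounds.

Measured so far in a functional assay on the whole organism with Rattus norvegicus as the target, at a dose of 100 mg/kg; a lower number here means less inhibition, a higher number more inhibition at the dose given (going by the name of the read-out):
compound 1, `CC/N=C(\S)NCCCCCCn1nc(-c2ccccc2)ccc1=O`: -5.6%
compound 2, `CN(C)/C(=N/CCCCn1nc(-c2ccccc2)ccc1=O)NC#N`: 80.7%
compound 3, `C/N=C(\S)NCCCCCn1nc(-c2ccccc2)ccc1=O`: 68.9%

Compound 3 stands second highest of the three; compound 2 lies above it and compound 1 far below it, both beyond the scatter.

Compound 4, `C/N=C(/NC#N)NCCCCCCn1nc(-c2ccccc2)ccc1=O`, is not yet measured. Its change from compound 3: a group of 8 heavy atoms (4 carbon, 4 nitrogen; no ring) in place of a group of 5 heavy atoms (2 carbon, 2 nitrogen, 1 sulfur; no ring), on a saturated chain carbon, five bonds along the chain from an aromatic nitrogen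

The step that bears on it is a number 11.8 percentage points lower from compound 2 to compound 3 (beyond the scatter), where the same entering group stood in place of a smaller sulfur-bearing group and read higher. Read in reverse, a modest rise is expected here. The larger step of a number 86.3 percentage points higher from compound 1 to compound 2 (beyond the scatter) involved a different leaving group and is less direct.

The expected step is a number 11.1 percentage points higher from compound 3 to compound 4 (beyond the scatter). Compound 4 is therefore estimated at 80%, with a range from 64% to 94%.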

Compound 4, a percentage reported as inhibition, in the whole organism at one dose (the size of the read-out at that dose, not a potency): 31.7%
Compound 4: the middle estimate sits 48.3 percentage points above what was measured, outside the stated range (below it).
By their numbers in this assay, from the lowest: compound 1; then compound 4; then compound 3; then compound 2.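

In this assay, the nitrile-bearing end group does not carry a rise with it at this place: against the sulfur-bearing group of compound 3 it gives a number 37.2 percentage points lower from compound 3 to compound 4 (beyond the scatter). Against the sulfur-bearing group of compound 1, the reading goes the other way, with a number 37.3 percentage points higher from compound 1 to compound 4 (beyond the scatter). An exchange of a sulfur-bearing end group for a nitrile-bearing one therefore has no single direction across these pairs, and nothing measured here accounts for the reversal.

Still open, from the compounds shown here alone, is how a urea end group, with oxygen in place of the sulfur, would read on the shared core. Going by these compounds, a simple amine at the chain end is equally open.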